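The source may report more compounds than this note shows. Statements on the series, on what has been measured and on what is new or still open speak of the compounds shown alone.

Compound 1 `O=C(N/N=C/c1ccc(F)cc1)Nc1cc2c(Nc3ccc(F)c(Cl)c3)ncnc2cc1O[C@H]1CCOC1`: 35100 nM
Compound 2 `COc1cc2ncnc(Nc3ccc(F)c(Cl)c3)c2cc1NC(=O)N/N=C/c1ccc(F)cc1`: 26600 nM

In a functional assay on A549 cells (Homo sapiens) for cytotoxicity, read by MTT assay, with a stated time of 72 h (on this read-out lower numbers stand for stronger inhibition and higher numbers for weaker inhibition), compound 2 gives 26600 nM, level with compound 1 within the scatter. Compound 3 `COc1cc2ncnc(Nc3ccc(F)c(Cl)c3)c2cc1NC(=O)N/N=C/c1ccc([N+](=O)[O-])cc1` departs from compound 2 at one place: nitro in place of fluoro on an aromatic carbon. This is nitro in place of fluoro on an aromatic carbon, 4-fluorophenyl to 4-nitrophenyl. For the measured compounds named here, the only measured step, a 1.3-fold lower number from compound 1 to compound 2 (0.12 log units; within the scatter), lies at a different place, so no measured step tests this change directly. With no evidence for a shift, none beyond the scatter is expected. The estimated 1.1-fold lower number from compound 2 to compound 3 (0.04 log units; within the scatter) is therefore small. For compound 3 the expected value is 24000 nM, with an estimated range of 9000 nM to 60000 nM.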

Compound 3, half-maximal inhibitory concentration: 35100 nM
Beside the measured number, compound 3's estimate is 1.5-fold (0.17 log units) below it, and the stated range covers the measured number.
By their numbers in this assay, from the lowest: compounds 2, 1 and 3 (each within the scatter of the next).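

In this assay, for the compounds shown here, the first measured change at this position, a 1.3-fold higher number from compound 2 to compound 3 (0.12 log units; within the scatter), leaves the number level within the scatter. Going from 4-fluorophenyl to 4-nitrophenyl, with nitro the larger group by heavy atoms, therefore brings no readable shift here. No measurement available bears on the reason for this flat result.

As far as these compounds go, whether an amine or a carboxylic acid on this aromatic carbon would move the number beyond the scatter stays open. The compounds shown hold no step beyond the scatter at either changed place, so neither place has yet shown any effect on this read-out.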